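Swapping the triazole arm for cyclopentyl on a weak Axl inhibitor

The source may hold more compounds than are shown below. What is called first, only, known or untested is meant among the compounds shown, and "the series" means these compounds.

Compound 1: `CNc1ncc2c(-c3ccc(N4CCN(C)CC4)nc3)nn(Cc3cn(Cc4ccccc4)nn3)c2n1`, 380 nM
Compound 2: `CCN1CCN(c2ccc(-c3nn(Cc4cn(Cc5ccccc5)nn4)c4nc(NC)ncc34)cn2)CC1`, > 10000 nM

Compound 2 `CCN1CCN(c2ccc(-c3nn(Cc4cn(Cc5ccccc5)nn4)c4nc(NC)ncc34)cn2)CC1` sits at the limit of an assay for inhibition of tyrosine-protein kinase receptor UFO (Homo sapiens), read by 33P incorporation, in the presence of a further agent that is not named here (a lower number here means a stronger inhibitor, a higher number a weaker inhibitor), as its value > 10000 nM is a limit and not a number; this is the limit of > 10000 nM in this assay, at which 1 of the 2 values shown sits. Compound 3 `CCN1CCN(c2ccc(-c3nn(CC4CCCC4)c4nc(NC)ncc34)cn2)CC1` differs from it by cyclopentyl in place of 1-benzyl-1H-1,2,3-triazol-4-yl on a saturated chain carbon bound to an aromatic nitrogen. Among the measured compounds shown here, the only measured step, an at least 26-fold higher number from compound 1 to compound 2 (1.42 log units; beyond the scatter), touches a different part of the molecule and gives no guide to this change. With compound 2 already at the limit, compound 3 is expected to stay weak, the step of an at least 1.2-fold lower number from compound 2 to compound 3 (0.09 log units; that floor lies within the scatter) being an estimate without direct support. Compound 3 is estimated at 8000 nM, within 1500 nM to 30000 nM.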

Compound 3, half-maximal inhibitory concentration: 260 nM
Beside the measured number, compound 3's estimate is 31-fold (1.49 log units) above it; the measured number lies below the stated range.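

In this assay, the group on the saturated chain carbon bound to an aromatic nitrogen strongly affects the read-out: cyclopentyl in place of 1-benzyl-1H-1,2,3-triazol-4-yl gives an at least 38-fold lower number from compound 2 to compound 3 (1.58 log units; beyond the scatter). Among the compounds shown here, the earlier step reached only a saturated chain carbon bound to an amine nitrogen in a ring, so this is the first evidence that a carbon-only ring at this place can return compound 3 to a measurable value. The value of compound 2 is a limit and not a number: the limit of > 10000 nM in this assay, at which 1 of the 3 values shown sits.

Which part of the benzyl triazole arm accounts for the step remains open. So does whether a cyclohexyl or an isopropyl group would serve here as cyclopentyl does.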